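The compounds below may be only part of what the source reports. "The series", "measured", "known", "first", "only" and "open" are said of these compounds alone.

Measured compounds in an ADME assay on MT4 cells (Homo sapiens) for cytotoxicity, with a stated time of 5 days; on this read-out lower numbers stand for higher toxicity in this test and higher numbers for lower toxicity in this test:
- compound 1, `CC(C)(C)C#Cc1cc(N(C(=O)[C@H]2CC[C@H](C)CC2)[C@H]2CC[C@H](Oc3ccccn3)CC2)c(C(=O)O)s1`, 100 nM
- compound 2, `CC1=CC[C@H](C(=O)N(c2cc(C#CC(C)(C)C)sc2C(=O)O)[C@H]2CC[C@](O)(CO[C@H]3CCOC3)CC2)CC1`, 12100 nM
- compound 3, `CC(C)(C)C#Cc1cc(N(C(=O)[C@H]2CC[C@H](C)CC2)[C@H]2CC[C@@](O)(CO[C@H]3CCOC3)CC2)c(C(=O)O)s1`, 18100 nM

Of these three, compound 1 stands at the lowest number, which on this read-out means the strongest cytotoxic effect; compound 2 and compound 3 both sit far higher, well beyond the usual scatter, so compound 1 is clearly the most toxic of the three in this assay.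

Compound 4, `CC(C)(C)C#Cc1cc(N(C(=O)[C@H]2CC[C@H](C)CC2)[C@H]2CC[C@H](OC3CCOC3)CC2)c(C(=O)O)s1`, has not yet been measured. It differs from compound 1 in one place: oxolan-3-yl in place of pyridin-2-yl on an oxygen on a saturated carbon. The ring attached to the oxygen on the saturated ring carbon is thus swapped from an aromatic six-membered ring for a non-aromatic five-membered one, while the rest of the molecule is unchanged.

For the measured compounds named here, no pair of measured compounds differs in only this one place, so no directly comparable step exists. Compound 2 and compound 3 do carry an oxolane ring and show much higher numbers than compound 1, but they differ from it in several places at once, so their values cannot be read as the effect of this change alone. The expectation for compound 4 is therefore a move toward less toxicity, a step of a 10-fold higher number from compound 1 to compound 4 (1.00 log units; beyond the scatter), but with wide uncertainty. The estimated value for compound 4 in this assay is 1000 nM, within a range from 200 nM to 8000 nM.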

Compound 4, half-maximal cytotoxic concentration: 3070 nM
Compound 4: middle estimate off by 3.1-fold (0.49 log units), on the low side; measured number inside the range.
By their numbers in this assay, from the lowest: compound 1; then compound 4; then compounds 2 and 3 (each within the scatter of the next).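

In this assay, putting oxolan-3-yl in place of pyridin-2-yl on an oxygen on a saturated carbon gives a 31-fold higher number from compound 1 to compound 4 (1.49 log units; beyond the scatter), a large step with the rest of the molecule unchanged. For the compounds shown here, the earlier compounds differ from one another and from compound 1 in several places at once, so this is the first clean reading of this position: swapping one aromatic six-membered ring for one non-aromatic five-membered ring moves the number well beyond the scatter, even though each group has the same count of hydrogen-bond acceptors and donors. Nothing available here tells why this swap has so large an effect.

The ring size and the aromatic character change together in this swap, so the compounds shown leave open which of the two goes with the step: a cyclopentyl ring or a phenyl ring on the same oxygen would begin to separate them. They also leave open how a ring carrying an amine, such as piperidin-4-yl, would read at this position.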